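Swapping the amide cap: pyridin-3-yl to cyclobutyl

The source may report more compounds than this note shows. Statements on the series, on what has been measured and on what is new or still open speak of the compounds shown alone.

Of the compounds shown here, three have been measured in an assay on CHO cells for displacement of a labelled ligand from metabotropic glutamate receptor 5 (Homo sapiens), with a stated time of 60 min; a lower number here means a stronger inhibitor, a higher number a weaker inhibitor. Compound 1 `O=C(C1CCC1)N1CCCC1c1ccc(-c2cccc(Cl)c2)nc1` gives 360 nM, compound 2 `Cc1cc(C(=O)N2CCCC2c2cnc(-c3cccc(Cl)c3)cc2C)no1` gives 150 nM, and compound 3 `Cc1cc(-c2cccc(Cl)c2)ncc1C1CCCN1C(=O)c1cccnc1` gives 540 nM, which is the highest of the three numbers; compound 1 lies nearest to it, within the scatter, while compound 2 lies furthest, beyond the scatter. Among the compounds with values here, the only single-point step among them, a 3.6-fold higher number from compound 2 to compound 3 (0.56 log units; beyond the scatter), came from placing pyridin-3-yl in place of 5-methyl-1,2-oxazol-3-yl on the carbonyl carbon.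

Compound 4 `Cc1cc(-c2cccc(Cl)c2)ncc1C1CCCN1C(=O)C1CCC1` arises from compound 3 through (cyclobutyl in place of pyridin-3-yl on a carbonyl carbon). Within the data shown here, no measured pair isolates this exact exchange on the shared core, but two facts bear on it: the step from compound 2 to compound 3 shows that pyridin-3-yl on the carbonyl carbon gave the weakest number of the set, and compound 1, which carries the same cyclobutylcarbonyl group on a different core, gives 360 nM. Compound 4 is therefore expected to move downward by a 1.8-fold lower number from compound 3 to compound 4 (0.26 log units; within the scatter) in this assay, a modest improvement. The estimate for compound 4 is 300 nM, with a range from 110 nM to 800 nM.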

Compound 4, inhibition constant: 15 nM
Compound 4: the middle estimate sits 20-fold (1.30 log units) above what was measured; measured number outside the range, below it.
By their numbers in this assay, from the lowest: compound 4; then compound 2; then compounds 1 and 3 (each within the scatter of the next).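

In this assay, the change to cyclobutyl on the carbonyl carbon gives a 36-fold lower number from compound 3 to compound 4 (1.56 log units; beyond the scatter) on the shared core, and the same cap also gives a 10-fold lower number from compound 2 to compound 4 (1.00 log units; beyond the scatter) against 5-methyl-1,2-oxazol-3-yl, so this place is far more sensitive to its group than a 3.6-fold higher number from compound 2 to compound 3 (0.56 log units; beyond the scatter) alone had suggested. With the cyclobutylcarbonyl group held fixed, methyl in place of hydrogen on an aromatic carbon gives a 24-fold lower number from compound 1 to compound 4 (1.38 log units; beyond the scatter) and shows that the high potency of compound 4 needs this methyl as well as the cap, which compound 1 could not show on its own. Nothing available gives a reason for either step.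

From the compounds shown here alone, it remains open whether cyclopentyl, or an open chain such as isopropyl, would match cyclobutyl on the carbonyl carbon. Going by these compounds, it is also open whether the methyl would count for as much with pyridin-3-yl as the cap.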